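The source may hold more compounds than are shown below. What is called first, only, known or untested is meant among the compounds shown, and "the series" means these compounds.

Measured so far:
- compound 1 `Nc1ccc(/C=C/C(=O)Nc2nnc(-c3ccccc3)[nH]2)cc1`: 1910000 nM in an ADME assay on Vero cells (Chlorocebus sabaeus) for cytotoxicity, read by MTT assay, with a stated time of 72 h; on this read-out lower numbers stand for higher toxicity in this test and higher numbers for lower toxicity in this test
- compound 2 `O=C(/C=C/c1ccc(O)cc1)Nc1nnc(-c2ccccc2)[nH]1`: 1850000 nM in this assay

Compound 2 has the lower of these two numbers, but the step of a 1.0-fold lower number from compound 1 to compound 2 (0.01 log units; within the scatter) lies within the scatter, so the two compounds cannot be told apart here. Compound 3 `O=C(/C=C/c1ccc([N+](=O)[O-])s1)Nc1nnc(-c2ccccc2)[nH]1` differs from compound 2 by 5-nitrothiophen-2-yl in place of 4-hydroxyphenyl on a double-bonded chain carbon bound to a double-bonded chain carbon. Within the data shown here, no measured step swaps one ring for another, so the only step known, a 1.0-fold lower number from compound 1 to compound 2 (0.01 log units; within the scatter), offers little guidance. The step of a 1.5-fold lower number from compound 2 to compound 3 (0.19 log units; within the scatter) is therefore an expectation with a wide range. For compound 3 the expected value in this assay is 1200000 nM, between 250000 nM and 3500000 nM.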

Compound 3, half-maximal cytotoxic concentration: 1670000 nM
Beside the measured number, compound 3's estimate is 1.4-fold (0.14 log units) below it; the range from low to high includes it.
By their numbers in this assay, from the lowest: compounds 3, 2 and 1 (each within the scatter of the next).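

Replacing 4-hydroxyphenyl with 5-nitrothiophen-2-yl gives a 1.1-fold lower number from compound 2 to compound 3 (0.04 log units; within the scatter) in this assay and replacing 4-aminophenyl with it gives a 1.1-fold lower number from compound 1 to compound 3 (0.06 log units; within the scatter) and both steps stay within the scatter. So at this place, on a double-bonded chain carbon, the whole ring can be exchanged, not just one group on it, with no readable change in the number. No evidence is available that bears on this result. The compounds shown leave open whether a carboxylic acid on the ring, a thiophene without the nitro group or a longer chain in place of the ring would also stay within the scatter.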